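The source may hold more compounds than are shown below. What is called first, only, known or untested is meant among the compounds shown, and "the series" means these compounds.

For the measured compounds named here, the three compounds measured so far share one core and differ only in the substituted benzyl group on the ring amine. In an assay on isolated protein for inhibition of Amine oxidase [flavin-containing] A (Homo sapiens), read by fluorescence, with stated times of 15 min and 20 min (on this read-out lower numbers stand for stronger inhibition and higher numbers for weaker inhibition), compound 1 `COc1ccc(CN2CCC(CCNC(=O)/C=C/c3cc(C(C)(C)C)c(O)c(C(C)(C)C)c3)CC2)cc1` gives 72500 nM, compound 2 `Cc1ccc(CN2CCC(CCNC(=O)/C=C/c3cc(C(C)(C)C)c(O)c(C(C)(C)C)c3)CC2)cc1` gives 70100 nM, and compound 3 `CC(C)(C)c1cc(/C=C/C(=O)NCCC2CCN(Cc3cccc(F)c3)CC2)cc(C(C)(C)C)c1O` gives 58400 nM. Compound 3 carries the lowest of the three numbers, but the others sit so close that a 1.2-fold lower number from compound 1 to compound 3 (0.09 log units; within the scatter) and a 1.2-fold lower number from compound 2 to compound 3 (0.08 log units; within the scatter) both fall within the scatter, as does a 1.0-fold lower number from compound 1 to compound 2 (0.01 log units; within the scatter). On these numbers compound 3 stands level with compound 1 and compound 2 rather than apart from them.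

Compound 4 `CC(C)(C)c1cc(/C=C/C(=O)NCCC2CCN(Cc3ccc(F)c(F)c3)CC2)cc(C(C)(C)C)c1O` is the next step: fluoro in place of hydrogen on an aromatic carbon. Every measured step bears on this same benzyl ring, swapping one substituent pattern for another, and none of them moved the number beyond the scatter. Nothing in the data singles out the added fluoro group as different from those earlier changes, so the expected step is a 1.1-fold lower number from compound 3 to compound 4 (0.03 log units; within the scatter), with no direction beyond the scatter claimed. Compound 4 is accordingly expected to give about 55000 nM in this assay, with a range from 25000 nM to 120000 nM.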

Compound 4, half-maximal inhibitory concentration: 64500 nM
For compound 4 the middle estimate is 1.2-fold (0.07 log units) below the measured one; the measured number falls inside the stated range.
By their numbers in this assay, from the lowest: compounds 3, 4, 2 and 1 (each within the scatter of the next).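

Adding a second fluoro group to the 3-fluorobenzyl group, on the aromatic carbon ortho to a fluoro group and para to a large group, gives the first step here in which only a hydrogen leaves, and in this assay it amounts to a 1.1-fold higher number from compound 3 to compound 4 (0.04 log units; within the scatter). The 3,4-difluorobenzyl group also stands level with the groups carrying a single substituent, with a 1.1-fold lower number from compound 2 to compound 4 (0.04 log units; within the scatter) and a 1.1-fold lower number from compound 1 to compound 4 (0.05 log units; within the scatter), so all four benzyl patterns on the shared core read alike in this assay, and a fluoro group at this place leaves the number within the scatter. No supporting measurement is available to explain this flat reading.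

From the compounds shown here alone, whether an amine or a carboxylic acid on this benzyl ring would move the number beyond the scatter remains open, as does the effect of a longer chain between the amide and the amine nitrogen in the ring. With all four compounds level, the series also does not show which parts of the shared core govern the inhibition seen in this assay.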